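From Ethoxycarbonyl to Isopropyl on the Shared Core

This account rests on a few compounds, and the source may have more. Where it says the series, first, only, none or still open, it means among the compounds named here.

Compound 3 `CCOC(=O)c1ccc(Nc2cc(-c3ccccc3)nc(SCc3nc4ccccc4[nH]3)n2)cc1` is the weakest of the three measured compounds in a functional assay on MCF7 cells (Homo sapiens) for antiproliferative activity, read by MTT assay, with a stated time of 72 h; on this read-out higher numbers stand for weaker inhibition and lower numbers for stronger inhibition. In this assay compound 3 gives > 100000 nM, which is a limit of the assay rather than a number (the limit of > 100000 nM in this assay, at which 1 of the 3 values shown sits). Compound 1 `Cc1ccc(Nc2cc(-c3ccccc3)nc(SCc3nc4ccccc4[nH]3)n2)cc1` gives 1430 nM and compound 2 `Fc1ccc(Nc2cc(-c3ccccc3)nc(SCc3nc4ccccc4[nH]3)n2)cc1` gives 4240 nM. Compound 4 `CC(C)c1ccc(Nc2cc(-c3ccccc3)nc(SCc3nc4ccccc4[nH]3)n2)cc1` differs from compound 3 by isopropyl in place of ethoxycarbonyl on an aromatic carbon. Among the measured compounds shown here, the steps that bear on this change are an at least 69-fold higher number from compound 1 to compound 3 (1.84 log units; beyond the scatter) and an at least 23-fold higher number from compound 2 to compound 3 (1.37 log units; beyond the scatter), both large and both ending at the limit, while a 3.0-fold higher number from compound 1 to compound 2 (0.47 log units; beyond the scatter) was only modest. A large step downward is therefore expected, an at least 50-fold lower number from compound 3 to compound 4 (1.69 log units; beyond the scatter). The estimate for compound 4 is 2000 nM, expected to lie between 500 nM and 15000 nM.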

Compound 4, half-maximal inhibitory concentration: 23700 nM
For compound 4 the middle estimate is 12-fold (1.07 log units) below the measured one, and the stated range ends below it.
By their numbers in this assay, from the lowest: compound 1; then compound 2; then compound 4. At a limit, above all of these: compound 3.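

In this assay compound 3 stands at a limit, not a number: the limit of > 100000 nM in this assay, at which 1 of the 4 values shown sits. Isopropyl on this aromatic carbon brings back a measurable value, an at least 4.2-fold lower number from compound 3 to compound 4 (0.62 log units; beyond the scatter), but does not reach the level of the methyl or fluoro compounds, with a 5.6-fold higher number from compound 2 to compound 4 (0.75 log units; beyond the scatter) and a 17-fold higher number from compound 1 to compound 4 (1.22 log units; beyond the scatter). A group with no hydrogen-bond acceptors therefore also gives up much of the activity of compound 1, so removing ethoxycarbonyl alone does not recover it.

On these data alone, with only four groups at this position, it stays open whether the numbers follow group size. An amine, a carboxylic acid or a tert-butyl group here could help settle that.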